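Chain extension at the ester and cytotoxicity readings

The source may hold more compounds than are shown below. What is called first, only, known or untested is meant among the compounds shown, and "the series" means these compounds.

Three esters of the shared core have been run. Compound 1 `CCCCCCOC(=O)CCC(=O)N1CCN(CCCOc2cc3c(Nc4ccc(F)c(Cl)c4)ncnc3cc2OC)CC1` gives 63.6% in a functional assay on A549 cells (Homo sapiens) for cytotoxicity, read by MTT assay, with a stated time of 24 h, tested at 60 uM; on this read-out lower numbers stand for a stronger effect and higher numbers for a weaker effect at the one concentration tested. Compound 2 `CCCCCCCCCCCOC(=O)CCC(=O)N1CCN(CCCOc2cc3c(Nc4ccc(F)c(Cl)c4)ncnc3cc2OC)CC1` gives 3.9% in this assay, and compound 3 `CCCCCCCCCCCCCOC(=O)CCC(=O)N1CCN(CCCOc2cc3c(Nc4ccc(F)c(Cl)c4)ncnc3cc2OC)CC1` gives 20.6%. Compound 3 thus stands second highest of the three numbers: the nearest number is reached by a number 16.7 percentage points higher from compound 2 to compound 3 (beyond the scatter), the furthest by a number 43 percentage points lower from compound 1 to compound 3 (beyond the scatter).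

Compound 4 `CCCCCCCCCCCCCCCCCOC(=O)CCC(=O)N1CCN(CCCOc2cc3c(Nc4ccc(F)c(Cl)c4)ncnc3cc2OC)CC1` has not been measured. Relative to compound 3 the change is butyl in place of hydrogen on a saturated chain carbon, ten or more bonds along the chain from an oxygen next to a carbonyl group. Going by the values given here, the steps that bear on it are all extensions of the same ester chain: a number 59.7 percentage points lower from compound 1 to compound 2 (beyond the scatter), a number 43 percentage points lower from compound 1 to compound 3 (beyond the scatter), and the one closest in kind, a number 16.7 percentage points higher from compound 2 to compound 3 (beyond the scatter). The first two extensions lowered the number strongly, the last raised it modestly, so the direction of a further extension is not settled, and a modest step in this assay is expected rather than a large one. For compound 4 the expected step is a number 9.4 percentage points higher from compound 3 to compound 4 (within the scatter). Compound 4 is therefore estimated at 30%, within 8% to 58%.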

Compound 4, a percentage reported as activity, at one concentration (the size of the read-out at that concentration, not a potency): 84.1%
Compound 4: the middle estimate sits 54.1 percentage points below what was measured, outside the stated range (above it).
By their numbers in this assay, from the lowest: compound 2; then compound 3; then compound 1; then compound 4.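

In this assay the butyl extension gives a number 63.5 percentage points higher from compound 3 to compound 4 (beyond the scatter) and is a large change at this place, not a modest one. The numbers therefore do not move one way with chain length: compound 2 holds the lowest of the four, the hexyl extension gives a number 80.2 percentage points higher from compound 2 to compound 4 (beyond the scatter) and the effect seen at compound 2 is lost on further lengthening. The undecyl extension gives a number 20.5 percentage points higher from compound 1 to compound 4 (beyond the scatter) and so leaves the number higher even than at the shortest ester, which means the longest chain shown reads as the weakest of the four in this assay.

Open, as far as these compounds go, is whether a longer chain continues this rise, and whether an amine or a carboxylic acid carried on the ester chain would alter it. Nothing at hand explains why the number turns upward along the chain.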